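Swapping a Methylphenyl Ketone for a Thiophene Ketone

This account rests on a few compounds, and the source may have more. Where it says the series, first, only, none or still open, it means among the compounds named here.

Of the compounds shown here, three sharing a boron-containing core have been tested in an ADME assay on L929 cells (Mus musculus) for cytotoxicity, read by resazurin assay, with a stated time of 72 h; on this read-out higher numbers stand for weaker inhibition and lower numbers for stronger inhibition. Compound 1, with the structure `COc1ccc(Sc2cn(-c3ccc4c(c3)B(O)OC4)c3ccccc23)cc1`, gives a value recorded only as the limit > 10 ug/mL. Compound 2, with the structure `OB1OCc2ccc(-n3cccc3Sc3ccccc3Cl)cc21`, likewise gives only the limit > 10 ug/mL. Compound 3, with the structure `Cc1cccc(C(=O)c2ccn(-c3ccc4c(c3)B(O)OC4)c2)c1`, also reaches only the limit > 10 ug/mL. So far, then, every result sits at the limit of > 10 ug/mL in this assay, at which 3 of the 3 values shown sit, and compound 3 stands where all of its companions do, with no number that would set it apart.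

The next compound, compound 4, has the structure `O=C(c1ccn(-c2ccc3c(c2)B(O)OC3)c1)c1cccs1`. It differs from compound 3 in one place: thiophen-2-yl in place of 3-methylphenyl on a carbonyl carbon. Among the compounds with values here, no measured pair shows what such an exchange does in this assay, so the expectation rests only on the limits seen so far. With nothing pointing toward stronger cytotoxicity, the step that the limit leaves unreadable from compound 3 to compound 4 is expected to stay within the scatter. Compound 4 is therefore estimated at 15 ug/mL, most likely again reported as a limit, with a range from 5 ug/mL to 40 ug/mL.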

Compound 4, half-maximal inhibitory concentration: > 10 ug/mL
Compound 4 ended at the assay's limit (the forecaster's own chance of this, stated with the estimate: 80%); the middle value lies beyond the limit too.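

Compound 3 and compound 4 both end at a limit, so the step between them cannot be read: the limit of > 10 ug/mL in this assay, at which 4 of the 4 values shown sit.

The compounds shown leave open how far past that limit each one lies, and whether any change on the shared core would give a readable number in this assay.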